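Cyanoethenyl for cyano on the diaryl ether series

The source may hold more compounds than are shown below. What is called first, only, known or untested is meant among the compounds shown, and "the series" means these compounds.

Measured so far in an ADME assay on HEK-293T cells (Homo sapiens) for cytotoxicity, with a stated time of 48 h; on this read-out higher numbers stand for lower toxicity in this test and lower numbers for higher toxicity in this test:
compound 1, `CCC(c1ccccc1)n1c(=O)[nH]c2ccc(Cl)cc21`: 55000 nM
compound 2, `CCn1c(=O)[nH]c2cccc(Oc3cc(Cl)cc(C#N)c3)c21`: 24100 nM
compound 3, `CCn1c(=O)[nH]c2cccc(Oc3cc(C#N)cc(C#N)c3)c21`: 96600 nM

Compound 3 holds the highest of the three numbers. For the measured compounds named here, its nearest neighbour is compound 1, which sits within the scatter of it; compound 2 lies furthest away, and that gap is beyond the scatter, as the single one-place step shows: a 4.0-fold higher number from compound 2 to compound 3 (0.60 log units; beyond the scatter).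

Compound 4, `CCn1c(=O)[nH]c2cccc(Oc3cc(C#N)cc(/C=C/C#N)c3)c21`, is not yet measured. It differs from compound 3 in one place: 2-cyanoethenyl in place of cyano on an aromatic carbon.

Going by the values given here, no measured step bears on this particular change. Among the compounds with values here, the one step on record, from chloro to cyano on the same ring, moved the number by a modest amount, but it swaps one small group for another and says nothing about extending a cyano group into a 2-cyanoethenyl group. Compound 1, with a different substitution pattern entirely, offers no guidance either. With nothing to lean on, the working expectation is no step beyond the scatter in this assay.

For compound 4 the estimate is 70000 nM, with a range from 25000 nM to 200000 nM. The expected step is a 1.4-fold lower number from compound 3 to compound 4 (0.14 log units; within the scatter), kept close to the value of compound 3 and wide in both directions.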

Compound 4, half-maximal cytotoxic concentration: 9700 nM
Compound 4: middle estimate off by 7.2-fold (0.86 log units), on the high side; measured number below the stated range.
By their numbers in this assay, from the lowest: compound 4; then compound 2; then compounds 1 and 3 (each within the scatter of the next).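

Working notes on the position: in this assay, the aromatic carbon meta to a cyano group does not tolerate every replacement alike, and extending the cyano group into a 2-cyanoethenyl group lowers the number beyond the scatter (a 10-fold lower number from compound 3 to compound 4 (1.00 log units; beyond the scatter)). The 2-cyanoethenyl group also falls short of the chloro group at the same place (a 2.5-fold lower number from compound 2 to compound 4 (0.40 log units; beyond the scatter)), so the number does not simply follow the presence of a nitrile at this carbon, since compound 4 and compound 3 both carry one there. Across compounds 2, 3 and 4, with the rest of the structure held constant, the three groups give three numbers separated beyond the scatter, with cyano highest, chloro in the middle and 2-cyanoethenyl lowest, and nothing at hand accounts for this order.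

The series leaves open whether the lower number goes with the added chain length or with the double bond, which a saturated 2-cyanoethyl group at this carbon would help to separate. Going by these compounds, how an amine or a carboxylic acid at the same place would read in this assay also remains open.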